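Changing the Amine Substituent: Expected Cytotoxicity of Compound 4

A few compounds are considered here, and "the series" means these few. Any claim that something is new, unique, unknown or untested is made for them only; others in the source may bear on it.

Compound 1, `Cc1nc(N)nc(N[C@@H]2C[C@H](CO)[C@@H](O)[C@H]2O)c1-c1nc2ccccc2s1`: in an ADME assay on cells (Homo sapiens) for cytotoxicity, read by polymerase chain reaction, with a stated time of 3 days (on this read-out lower numbers stand for higher toxicity in this test and higher numbers for lower toxicity in this test), compound 1 gives 4000 nM.
Compound 2, `Cc1nc(NC(C)C)nc(N[C@@H]2C[C@H](CO)[C@@H](O)[C@H]2O)c1-c1nc2ccccc2s1`: in this assay compound 2 gives 13000 nM.
Compound 3, `Cc1nc(NCC2CCC2)nc(N[C@@H]2C[C@H](CO)[C@@H](O)[C@H]2O)c1-c1nc2ccccc2s1`: in this assay compound 3 gives only a limit of the assay, > 25000 nM.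

Compound 3 thus stands at the top of the measured range, sitting at the limit of > 25000 nM in this assay, at which 1 of the 3 values shown sits, rather than at a number. The measured steps all concern the group on the ring nitrogen of the shared core: a 3.3-fold higher number from compound 1 to compound 2 (0.51 log units; beyond the scatter), and an at least 6.2-fold higher number from compound 1 to compound 3 (0.79 log units; beyond the scatter). Between the two substituted compounds the step is smaller: an at least 1.9-fold higher number from compound 2 to compound 3 (0.28 log units; that floor lies within the scatter).

Compound 4 is `Cc1nc(NCCOC(C)C)nc(N[C@@H]2C[C@H](CO)[C@@H](O)[C@H]2O)c1-c1nc2ccccc2s1`. The change from compound 3 is isopropoxymethyl in place of cyclobutyl on a saturated chain carbon bound to a nitrogen on an aromatic ring. Among the measured compounds shown here, the entering group is close in size to the one that leaves, so the earlier steps, which turned on adding bulk to a bare nitrogen, say little about this exchange; the nearest comparison, the step from compound 2 to compound 3, stayed within the scatter.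

For compound 4 a step of a number no higher from compound 3 to compound 4 (the limit leaves the size open) is therefore expected, that is, no change beyond the scatter. Compound 4 is estimated at 25000 nM, with a range from 9000 nM to 60000 nM, and there is a fair chance that, like compound 3, it is reported only as a limit.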

Compound 4, half-maximal cytotoxic concentration: 8000 nM
Estimate against measurement, compound 4: 3.1-fold (0.49 log units) above; the whole stated range lies above it.
By their numbers in this assay, from the lowest: compounds 1, 4 and 2 (each within the scatter of the next, the first and the last beyond it). At a limit, above all of these: compound 3.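

Exchanging cyclobutyl for isopropoxymethyl on this saturated chain carbon is not a silent swap: in this assay there is an at least 3.1-fold lower number from compound 3 to compound 4 (0.49 log units; beyond the scatter), and on this read-out a lower number stands for higher toxicity in this test. The lower toxicity that came with isopropyl and cyclobutylmethyl on the nitrogen is therefore not shared by every group placed there, since the printed steps a 2.0-fold higher number from compound 1 to compound 4 (0.30 log units; within the scatter) and a 1.6-fold lower number from compound 2 to compound 4 (0.21 log units; within the scatter) leave compound 4 unresolved from both compound 1 and compound 2. The full size of the step from the cyclobutylmethyl compound stays unknown because compound 3 is reported only as a limit: the limit of > 25000 nM in this assay, at which 1 of the 4 values shown sits.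

This change removes a ring and brings in an oxygen with its hydrogen-bond acceptor in one move, so the compounds shown do not separate the two. A branched all-carbon chain on the nitrogen would speak to the loss of the ring alone, while a hydroxyl or an amine at the end of the chain would show whether the kind of heteroatom there matters.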